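Anilino exchange on the shared core: compound 3 to compound 4

This account rests on a few compounds, and the source may have more. Where it says the series, first, only, none or still open, it means among the compounds named here.

Compound 3 `Fc1cccc(-c2nc(Nc3cccc(Cl)c3)c3cc(F)ccc3n2)c1` gives > 50000 nM in a functional assay on U-937 cells (Homo sapiens) for cytotoxicity, read by MTT assay, with a stated time of 48 h (on this read-out higher numbers stand for weaker inhibition and lower numbers for stronger inhibition), which is a limit of the assay rather than a number (the limit of > 50000 nM in this assay, at which 1 of the 3 values shown sits). For comparison, compound 1 `Fc1cccc(Nc2nc(-c3cccc(F)c3)nc3ccc(F)cc23)c1` gives 42300 nM and compound 2 `Fc1cccc(-c2nc(Nc3ccc(Cl)cc3)c3cc(F)ccc3n2)c1` gives 32700 nM. Compound 4 `Fc1cccc(-c2nc(Nc3ccc(Br)cc3)c3cc(F)ccc3n2)c1` differs from compound 3 in one place: 4-bromophenyl in place of 3-chlorophenyl on a nitrogen on an aromatic ring. The measured step that bears most on it is an at least 1.5-fold higher number from compound 2 to compound 3 (0.18 log units; that floor lies within the scatter), a 4-chlorophenyl against a 3-chlorophenyl on the same nitrogen; the other, a 1.3-fold lower number from compound 1 to compound 2 (0.11 log units; within the scatter), also lies within the scatter. A step back toward the number of compound 2 is therefore the most that is expected, with nothing beyond the scatter. Compound 4 is expected at 38000 nM, between 18000 nM and 80000 nM, an expected step of an at least 1.3-fold lower number from compound 3 to compound 4 (0.11 log units; that floor lies within the scatter).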

Compound 4, half-maximal inhibitory concentration: > 50000 nM
Compound 4: only a limit was reported; the forecaster's own chance of this, stated with the estimate: 40%; middle value at least 1.3-fold (0.11 log units) from the limit.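

In this assay compound 4 gives > 50000 nM as a limit, not a number. The step from compound 3 cannot be read, because both values are limits: the limit of > 50000 nM in this assay, at which 2 of the 4 values shown sit. Of the readable steps, bromo in place of chloro on an aromatic carbon gives an at least 1.5-fold higher number from compound 2 to compound 4 (0.18 log units; that floor lies within the scatter) and 4-bromophenyl in place of 3-fluorophenyl on the nitrogen gives an at least 1.1-fold higher number from compound 1 to compound 4 (0.07 log units; that floor lies within the scatter) and so neither separates compound 4 from its neighbours.

From the compounds shown here alone, whether any group on this phenyl gives a clear change remains open. An amine or a carboxylic acid in place of the halogen could test this.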